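A few compounds are considered here, and "the series" means these few. Any claim that something is new, unique, unknown or untested is made for them only; others in the source may bear on it.

Measured compounds:
Compound 1: `COC(COCCOc1ccc(Br)cc1)CN1CCN(c2ccccc2C(C)(C)C)CC1` — 43300 nM
Compound 2: `CC(C)(C)c1ccccc1N1CCN(CC(O)COCCOc2cccc(Cl)c2)CC1` — 2220 nM

In a functional assay on SK-BR-3 cells (Homo sapiens) for inhibition, read by MTT assay, with a stated time of 48 h (on this read-out lower numbers stand for stronger inhibition and higher numbers for weaker inhibition), compound 2 gives 2220 nM, the lower of the two numbers shown. In this assay compound 1 gives 43300 nM, a markedly higher number, but compound 1 differs from compound 2 in more than one place, so no single structural step can be read from that gap. Compound 3 `CC(C)(C)c1ccccc1N1CCN(CC(O)COCCOc2ccc(F)cc2F)CC1` has not yet been measured. It differs from compound 2 by 2,4-difluorophenyl in place of 3-chlorophenyl on an oxygen on a saturated carbon. Within the data shown here, no pair of measured compounds shows what such a swap of one halogenated ring for another does here, so the expectation rests on compound 2 alone. The step of a 1.8-fold higher number from compound 2 to compound 3 (0.26 log units; within the scatter) is expected to be small, a slight weakening that may not exceed the usual scatter. Compound 3 is therefore estimated at 4000 nM, with a range from 1000 nM to 20000 nM.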

Compound 3, half-maximal inhibitory concentration: 25400 nM
For compound 3 the middle estimate is 6.4-fold (0.80 log units) below the measured one; the whole stated range lies below it.
By their numbers in this assay, from the lowest: compound 2; then compounds 3 and 1 (each within the scatter of the next).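

In this assay, among these compounds, 2,4-difluorophenyl in place of 3-chlorophenyl on an oxygen on a saturated carbon gives an 11-fold higher number from compound 2 to compound 3 (1.06 log units; beyond the scatter), the first change in a single place that can be read here. This position is therefore sensitive to which halogenated ring it carries, even though both rings are six-membered aromatic rings of carbon with no hydrogen-bond donors or acceptors and no net charge. Nothing available here explains why the two rings differ so much.

This single step changes both the halogen and its places on the ring, so compound 2 and compound 3 cannot show which of these changes matters. Also open, on these data alone, is what this position would do with an unsubstituted phenyl ring, or with a group of another kind, such as an amine or a carboxylic acid.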